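Swapping Butyl for Isopropyl on a Ring Carbon

The compounds below may be only part of what the source reports. "The series", "measured", "known", "first", "only" and "open" are said of these compounds alone.

Measured so far:
compound 1, `CC1(C)CC(=O)N(c2ccccc2C(=O)OCC2CCCN(CCCc3ccccc3)C2)C1=O`: 7500 nM
compound 2, `CCCCC1CC(=O)N(c2ccccc2C(=O)OCC2CCCN(CCCc3ccccc3)C2)C1=O`: 1500 nM

Among the measured compounds shown here, in a functional assay with Neuronal acetylcholine receptor; alpha3/beta4 (Homo sapiens) as the target (a higher number here means a weaker inhibitor, a lower number a stronger inhibitor), compound 2 stands lowest of the two numbers; the only step on record, a 5.0-fold lower number from compound 1 to compound 2 (0.70 log units; beyond the scatter), separates it from compound 1, which sits above it beyond the scatter.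

Compound 3, `CC(C)C1CC(=O)N(c2ccccc2C(=O)OCC2CCCN(CCCc3ccccc3)C2)C1=O`, has not been measured yet. It differs from compound 2 by isopropyl in place of butyl on a saturated ring carbon.

For the measured compounds named here, only one measured step bears on this change: a 5.0-fold lower number from compound 1 to compound 2 (0.70 log units; beyond the scatter), in which the group on that same ring carbon was replaced by a larger one and the number fell by a modest amount. Isopropyl is the shorter and branched group relative to butyl, so the direction here is expected to run the other way, though with a smaller shift, since the change from butyl to isopropyl is less extensive than the one behind a 5.0-fold lower number from compound 1 to compound 2 (0.70 log units; beyond the scatter). Compound 3 is therefore expected to be a somewhat weaker inhibitor than compound 2, with an estimated step of a 1.7-fold higher number from compound 2 to compound 3 (0.22 log units; within the scatter), close to the scatter. The estimate for compound 3 in this assay is 2500 nM, within a range of 1200 nM to 6000 nM.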

Compound 3, half-maximal inhibitory concentration: 2500 nM
Beside the measured number, compound 3's estimate shows no gap at the digits printed, within the range that was stated.
By their numbers in this assay, from the lowest: compounds 2 and 3 (each within the scatter of the next); then compound 1.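

In this assay the exchange of butyl for isopropyl on this saturated ring carbon gives a 1.7-fold higher number from compound 2 to compound 3 (0.22 log units; within the scatter) and so does not separate the two groups, even though one is a straight chain and the other is branched. Compound 3 still stands clearly apart from compound 1 by a 3.0-fold lower number from compound 1 to compound 3 (0.48 log units; beyond the scatter) and, taken with the earlier step, this shows that the lower number is not confined to butyl but is shared by two different alkyl groups at this ring carbon. The compounds shown offer no measurement that accounts for either step, so the reason for this pattern stays unknown.

From the compounds shown here alone, what remains open is how far this tolerance extends, as three compounds cannot show whether a longer chain such as hexyl would lower the number further or whether a methyl group alone would already match isopropyl. It is equally unclear whether a ring such as cyclohexyl or phenyl, or a group of another kind such as an amine or a carboxylic acid, would fit the same pattern at this ring carbon.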